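The source may hold more compounds than are shown below. What is called first, only, known or untested is meant among the compounds shown, and "the series" means these compounds.

Measured so far in a functional assay on NIH3T3 cells (Mus musculus); on this read-out lower numbers stand for an effect already at smaller amounts and higher numbers for an effect only at larger amounts of compound:
- compound 1 `Cn1cncc1C(OCc1ccc(C#N)cc1-c1ccc(F)c(Cl)c1)c1ccc(C#N)nc1`: 46 nM
- compound 2 `Cn1cncc1C(OCc1ccc(C#N)nc1-c1ccc(OC(F)(F)F)cc1)c1ccc(C#N)cc1`: 4 nM

Of these two numbers, compound 2 has the lower, and the gap up to compound 1 lies beyond the usual scatter of repeat measurements. Compound 3 `Cn1cncc1C(OCc1ccc(C#N)nc1-c1cccc(Cl)c1)c1ccc(C#N)cc1` has not yet been measured in this assay. It keeps the core of compound 2 and changes one group, with 3-chlorophenyl in place of 4-(trifluoromethoxy)phenyl on an aromatic carbon, next to the ring nitrogen: 3-chlorophenyl in place of 4-(trifluoromethoxy)phenyl on an aromatic carbon. Among the compounds with values here, no measured pair isolates this change, so the evidence is thin. Compound 1, at 46 nM, also carries a chlorine-bearing phenyl group, but it differs from compound 2 in more than one place, so it offers only a loose hint of a higher number. A moderate rise beyond the scatter is expected, a 3.8-fold higher number from compound 2 to compound 3 (0.57 log units; beyond the scatter). For compound 3 the estimate is 15 nM, with an expected range of 4 nM to 60 nM.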

Compound 3, half-maximal effective concentration: 1.8 nM
Compound 3: the middle estimate sits 8.3-fold (0.92 log units) above what was measured; the measured number lies below the stated range.
By their numbers in this assay, from the lowest: compound 3; then compound 2; then compound 1.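

In this assay, putting 3-chlorophenyl in place of 4-(trifluoromethoxy)phenyl on the aromatic carbon next to the ring nitrogen gives a 2.2-fold lower number from compound 2 to compound 3 (0.35 log units; beyond the scatter). The entering group is the smaller one, with fewer heavy atoms and no hydrogen-bond acceptor, so the larger group of compound 2 is not required here for a low number. No measurement at hand speaks to the cause of this step.

This single pair changes both the substituent and the numbered place it holds on the phenyl ring, so it cannot show which of the two matters. As far as these compounds go, how 4-chlorophenyl, unsubstituted phenyl or a non-aromatic group such as an amine would read at this position remains open.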